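Adding ethoxy to the phenyl ring of compound 1

The source may hold more compounds than are shown below. What is called first, only, known or untested is meant among the compounds shown, and "the series" means these compounds.

Among the compounds with values here, in a functional assay on A549 cells (Homo sapiens) for antiproliferative activity, read by MTT assay, with a stated time of 48 h (a higher number here means a weaker inhibitor of growth, a lower number a stronger inhibitor of growth), compound 1 `COC(=O)N1N=C(c2ccccc2)CC1c1cc(OC)c(OC)c(OC)c1` gives 2880 nM, the lowest of the three numbers so far. Compound 2 `CCOC(=O)N1N=C(c2ccccc2)CC1c1cc(OC)c(OC)c(OC)c1` gives 6680 nM, and compound 3 `COC(=O)N1N=C(c2ccccc2)CC1c1ccc(OC)c(OC)c1` gives 7320 nM.

Compound 4 `CCOc1cccc(C2=NN(C(=O)OC)C(c3cc(OC)c(OC)c(OC)c3)C2)c1` keeps the core of compound 1 and differs in one place: ethoxy in place of hydrogen on an aromatic carbon. Within the data shown here, no measured step touches that ring, so the evidence is indirect. The step of a 2.3-fold higher number from compound 1 to compound 2 (0.37 log units; beyond the scatter) adds a methyl elsewhere in the molecule, and the step of a 2.5-fold higher number from compound 1 to compound 3 (0.41 log units; beyond the scatter) removes a methoxy from the other aromatic ring. Both are modest and both raise the number, but two steps make a thin basis for predicting direction.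

A modest rise of similar size is therefore expected in this assay, though a result close to compound 1 would not be surprising. The expected step is a 1.5-fold higher number from compound 1 to compound 4 (0.16 log units; within the scatter). For compound 4 the estimated value is 4200 nM, with an expected range of 1400 nM to 12000 nM.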

Compound 4, concentration for 50% growth inhibition: 5290 nM
Estimate against measurement, compound 4: 1.3-fold (0.10 log units) below, within the range that was stated.
By their numbers in this assay, from the lowest: compounds 1, 4, 2 and 3 (each within the scatter of the next, the first and the last beyond it).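

Within the data shown here, the phenyl ring of compound 1 now carries a substituent for the first time: in this assay the change from phenyl to 3-ethoxyphenyl gives a 1.8-fold higher number from compound 1 to compound 4 (0.26 log units; within the scatter). Unlike the two earlier steps, which lie beyond the scatter, this one cannot be told apart from repeat measurement. This carbon, meta to a large group, therefore accepts ethoxy with no resolved change in growth inhibition. Nothing available bears on why the ring accepts this group.

A single group at a single ring position is all that is shown here, and whether other positions on this ring behave alike remains open. Also open, going by these compounds, is whether an amine, a carboxylic acid or a longer chain such as butoxy at this carbon would stay within the scatter of compound 1.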